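A few compounds are considered here, and "the series" means these few. Any claim that something is new, unique, unknown or untested is made for them only; others in the source may bear on it.

Measured so far in an assay for inhibition of Tryptophan 2,3-dioxygenase (Homo sapiens), with a stated time of 1 h, tested at 10 uM; a higher number here means more inhibition at the concentration tested (going by the name of the read-out), a lower number less inhibition:
compound 1, `FC(F)(F)c1cccc(CNc2cc(Br)cc3[nH]ncc23)c1`: 56%
compound 2, `Oc1ccc(CNc2cc(Br)cc3[nH]ncc23)c(O)c1`: "not active" (no number reported)
compound 3, `Oc1ccc(CNc2cc(Br)cc3[nH]ncc23)c(F)c1`: "not active" (no number reported)

Only compound 1 gives a number in this assay. Compound 3 stands without one: it was reported as "not active" (no number reported), as was compound 2, so its level is known only as being too low to report. The next compound, compound 4, has the structure `Cc1cc(O)ccc1CNc1cc(Br)cc2[nH]ncc12`. It differs from compound 3 in one place: methyl in place of fluoro on an aromatic carbon. Among the measured compounds shown here, no step between two measured compounds is available to set a size or direction for this change, and compound 3 itself offers no number to start from. The expectation is therefore a low value again, with no step beyond the scatter: compound 4 is estimated at 15%, between 0% and 40%.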

Compound 4, a percentage reported as inhibition, at one concentration (the size of the read-out at that concentration, not a potency): 19%
Beside the measured number, compound 4's estimate is 4 percentage points below it; the range from low to high includes it.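

Among the compounds shown here, compound 3 has no number in this assay while compound 4 gives 19% there, so no step between the two can be read. No other data shown bear on this result. On these data alone, what swapping fluoro for methyl does to inhibition stays open.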